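The source may report more compounds than this note shows. Statements on the series, on what has been measured and on what is new or still open speak of the compounds shown alone.

Measured in a functional assay on Caco-2 cells (Homo sapiens) for inhibition, read by MTT assay, with a stated time of 48 h, tested at 10 uM; a higher number here means more inhibition of growth at the concentration tested, a lower number less inhibition of growth:
- compound 1 `Cc1oc2c([C@H]3CCN(C)C[C@H]3O)c(O)cc(O)c2c(=O)c1C(O)c1ccc([N+](=O)[O-])cc1`: 5%
- compound 2 `Cc1oc2c([C@H]3CCN(C)C[C@H]3O)c(O)cc(O)c2c(=O)c1C(O)c1ccc(Cl)cc1`: 3%

Compound 2, at 3%, stands level with compound 1 within the scatter. Compound 3 `Cc1oc2c([C@H]3CCN(C)C[C@H]3O)c(O)cc(O)c2c(=O)c1C(O)c1cccc(Cl)c1` carries one change from compound 2: 3-chlorophenyl in place of 4-chlorophenyl on a saturated chain carbon bound to an aromatic carbon and an oxygen on a saturated carbon, with 3-chlorophenyl in place of 4-chlorophenyl on a saturated chain carbon bound to an aromatic carbon and an oxygen on a saturated carbon. Going by the values given here, the only measured step, a number 2 percentage points lower from compound 1 to compound 2 (within the scatter), exchanges nitro for chloro, and no measured step tests this change directly. The expected step, a number 2 percentage points higher from compound 2 to compound 3 (within the scatter), is therefore none beyond the scatter in this assay. The estimate for compound 3 is 5%, with an expected range of 0% to 15%.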

Compound 3, percent growth inhibition at one concentration: 4%
Compound 3: the middle estimate sits 1 percentage points above what was measured; low and high end bracket the measured number.
By their numbers in this assay, from the lowest: compounds 2, 3 and 1 (each within the scatter of the next).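

In this assay, the change from 4-chlorophenyl to 3-chlorophenyl on the saturated chain carbon bound to an aromatic carbon and an oxygen on a saturated carbon gives a number 1 percentage points higher from compound 2 to compound 3 (within the scatter). At the same place, 3-chlorophenyl in place of 4-nitrophenyl gives a number 1 percentage points lower from compound 1 to compound 3 (within the scatter), so neither the shift of the chlorine nor this exchange separates these compounds in this assay. Nothing available explains this result. Still open, as far as these compounds go, is whether an amine or a carboxylic acid on the phenyl group would move the number beyond the scatter.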